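The source may report more compounds than this note shows. Statements on the series, on what has been measured and on what is new or still open speak of the compounds shown alone.

Of the compounds shown here, three sharing one core have been measured so far in a functional assay on K562 cells (Homo sapiens) for cytotoxicity, read by trypan blue exclusion, with a stated time of 96 h; a lower number here means a stronger inhibitor, a higher number a weaker inhibitor. Compound 1 `COc1cc(OC)c(/C=C/S(=O)(=O)Nc2ccc(OC)c(N)c2)c(OC)c1` has hydrogen on a nitrogen on an aromatic ring and reads 3 nM as the lowest number. Compound 2 `COC(=O)C(C)(C)Nc1cc(NS(=O)(=O)/C=C/c2c(OC)cc(OC)cc2OC)ccc1OC` has 1-(methoxycarbonyl)-1-methylethyl on that nitrogen and reads 300 nM as the highest. Compound 3 `COc1cc(OC)c(/C=C/S(=O)(=O)Nc2ccc(OC)c(NCC(=O)O)c2)c(OC)c1` has carboxymethyl there and reads 20 nM as the second highest of the three numbers.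

Compound 4 `COc1cc(OC)c(/C=C/S(=O)(=O)Nc2ccc(OC)c(NC(C(=O)O)c3ccc(F)cc3)c2)c(OC)c1` comes from compound 3 by one change 4-fluorophenyl in place of hydrogen on a saturated chain carbon bound to a carbonyl carbon and a nitrogen on an aromatic ring with 4-fluorophenyl in place of hydrogen on a saturated chain carbon bound to a carbonyl carbon and a nitrogen on an aromatic ring. The nearest evidence is modest: a 6.7-fold higher number from compound 1 to compound 3 (0.82 log units; beyond the scatter) for adding carboxymethyl, against a 100-fold higher number from compound 1 to compound 2 (2.00 log units; beyond the scatter) for the larger group. Among the measured compounds shown here, the step of a 15-fold lower number from compound 2 to compound 3 (1.18 log units; beyond the scatter) runs the other way, but it swaps the whole group, so no measured step isolates a change on this chain carbon. A modest rise in this assay is therefore expected, with an estimated 2.5-fold higher number from compound 3 to compound 4 (0.40 log units; beyond the scatter) as its size. Compound 4 is expected at 50 nM with an estimated range from 10 nM to 250 nM as its bounds.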

Compound 4, half-maximal inhibitory concentration: 20 nM
Beside the measured number, compound 4's estimate is 2.5-fold (0.40 log units) above it, and the stated range covers the measured number.
By their numbers in this assay, from the lowest: compound 1; then compounds 3 and 4 (each within the scatter of the next); then compound 2.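

In this assay, the saturated chain carbon bound to a carbonyl carbon and a nitrogen on an aromatic ring takes 4-fluorophenyl in place of hydrogen with no change at the digits printed from compound 3 to compound 4 (within the scatter), so adding this ring at this position leaves the reading where it was. Compound 4 therefore keeps the standing of compound 3 against the other two, with a 6.7-fold higher number from compound 1 to compound 4 (0.82 log units; beyond the scatter) and a 15-fold lower number from compound 2 to compound 4 (1.18 log units; beyond the scatter): the added ring moves the number neither back toward that of compound 1 nor out toward that of compound 2. Nothing at hand explains why this position accepts the ring in this way.

The compounds shown leave open whether a plain phenyl, a methyl or a longer alkyl chain on this same carbon would also leave the number in place. They also leave open whether a primary amide in place of the carboxylic acid would keep the reading of compound 4.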